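This account rests on a few compounds, and the source may have more. Where it says the series, first, only, none or still open, it means among the compounds named here.

Compound 1 `O=C(O)Cc1nn(Cc2nc3cc(Cl)ccc3s2)c(=O)c2ccccc12` — in an in vivo functional assay on the whole organism for inhibition of sorbitol dehydrogenase (Rattus norvegicus), at a dose of 10 mg/kg by the oral route (a lower number here means less inhibition, a higher number more inhibition at the dose given (going by the name of the read-out)), compound 1 gives 73%.
Compound 2 `O=C(O)Cc1nn(Cc2nc3ccc(C(F)(F)F)cc3s2)c(=O)c2ccccc12` — in this assay compound 2 gives 65%.
Compound 3 `O=C(O)Cc1nn(Cc2nc3cccc(Cl)c3s2)c(=O)c2ccccc12` — in this assay compound 3 gives 52%.

Among these three, compound 3 stands lowest. The nearest number to it belongs to compound 2, which sits higher by a margin beyond the usual scatter, and the furthest belongs to compound 1, which sits higher still, again beyond the scatter. Among the measured compounds shown here, none of the three pairs differs in only one place, so no single step between measured compounds can be followed here; only the three values themselves are known.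

Compound 4 `O=C(O)Cc1nn(Cc2nc3cccc(Br)c3s2)c(=O)c2ccccc12` is the next compound to be measured in this assay. It differs from compound 3 in one place: bromo in place of chloro on an aromatic carbon. For the measured compounds named here, nothing among the measured compounds shows what such a swap of one halogen for another does in this assay, so the expectation rests only on the closeness of the two groups in what is counted. The change is expected to move the read-out little, in no firm direction, and a step within the scatter is the most likely outcome.

Compound 4 is therefore expected to give about 55% in this assay, with a range from 38% to 72%. This estimate means a step of a number 3 percentage points higher from compound 3 to compound 4 (within the scatter), which is expected to stay within the scatter.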

Compound 4, a percentage reported as inhibition, in the whole organism at one dose (the size of the read-out at that dose, not a potency): 71%
Compound 4: middle estimate off by 16 percentage points, on the low side; low and high end bracket the measured number.
By their numbers in this assay, from the lowest: compound 3; then compounds 2, 4 and 1 (each within the scatter of the next).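

On an aromatic carbon ortho to a fused ring and meta to a fused ring, one halogen cannot simply stand in for the other in this assay: bromo in place of chloro brings a number 19 percentage points higher from compound 3 to compound 4 (beyond the scatter) with no other change to the compound. Chloro and bromo match in everything counted here, each being one heavy atom with no ring, no hydrogen-bond donors or acceptors and no net charge, so those counts do not separate the two groups, although the read-out does. Nothing available explains the size or direction of this step.

This single pair sets no trend across the halogens, and it leaves open where fluoro, iodo, methyl or methoxy would fall at this position. It also leaves open whether bromo in place of chloro would bring a similar step at the other chloro-bearing position seen in compound 1, and, since the read-out comes from one oral dose, whether the step would hold at other doses.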